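The source may hold more compounds than are shown below. What is called first, only, known or untested is meant among the compounds shown, and "the series" means these compounds.

Measured so far:
- compound 1 `CCCCCCCCCCn1cc(/C=[N+](\[O-])c2ccccc2)nn1`: 9900 nM
- compound 2 `CCCCCCCCn1cc(/C=[N+](\[O-])C(C)(C)C)nn1`: 7900 nM

In a functional assay on THP-1 cells (Homo sapiens) for inhibition, read by ELISA, with stated times of 2 h and 48 h (a higher number here means a weaker inhibitor, a lower number a stronger inhibitor), compound 2 at 7900 nM stands within the scatter of compound 1 at 9900 nM. Compound 3 `CCCCCCCCCCn1cc(/C=[N+](\[O-])C(C)(C)C)nn1` departs from compound 2 by ethyl in place of hydrogen on a saturated chain carbon, eight bonds along the chain from an aromatic nitrogen. Among the measured compounds shown here, no measured pair isolates this change, so no direction is favoured, and no effect beyond the scatter is expected in this assay. The estimate amounts to a 1.1-fold lower number from compound 2 to compound 3 (0.02 log units; within the scatter), an expected step of minor size. For compound 3 the expected value is 7500 nM, with an estimated range of 3000 nM to 16000 nM.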

Compound 3, half-maximal inhibitory concentration: 20000 nM
Beside the measured number, compound 3's estimate is 2.7-fold (0.43 log units) below it; the measured number lies above the stated range.
By their numbers in this assay, from the lowest: compounds 2 and 1 (each within the scatter of the next); then compound 3.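

In this assay, ethyl in place of hydrogen on a saturated chain carbon, eight bonds along the chain from an aromatic nitrogen, gives a 2.5-fold higher number from compound 2 to compound 3 (0.40 log units; beyond the scatter) and shows that this chain position is not silent. With the chain of compound 3 held fixed, tert-butyl in place of phenyl on a double-bonded nitrogen gives a 2.0-fold higher number from compound 1 to compound 3 (0.31 log units; beyond the scatter) and leaves compound 3 the weakest of the three. Nothing at hand accounts for either step.

Open, on these data alone, is whether a longer chain continues this trend. Also open, as far as these compounds go, is how a chain carrying an amine or a carboxylic acid would compare.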